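This account rests on a few compounds, and the source may have more. Where it says the series, first, only, none or still open, it means among the compounds named here.

Compound 2, with the structure `O=C(/C(=C\c1ccc[nH]1)SCc1ccc(Cl)cc1)c1ccc(Cl)cc1`, is one of three thioether enones assayed in a functional assay on DU-145 cells (Homo sapiens) for inhibition, read by trypan blue exclusion, with a stated time of 96 h; on this read-out higher numbers stand for weaker inhibition of growth and lower numbers for stronger inhibition of growth. In this assay compound 2 gives 10000 nM. Compound 1, `Cc1ccc(S/C(=C/c2ccc[nH]2)C(=O)c2ccc(Cl)cc2)cc1`, carries a 4-methylphenyl on the sulfur instead, and in this assay compound 1 gives 10000 nM; the step of no change at the digits printed from compound 1 to compound 2 (within the scatter) lies within the scatter. Compound 3, `O=C(/C(=C\c1ccc(O)c([N+](=O)[O-])c1)SCc1ccc(Br)cc1)c1ccc(Br)cc1`, differs from compound 2 in more than one place; in this assay compound 3 gives 10000 nM, so compound 2 stands level with both of its neighbours and none can be called more or less active than another.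

Compound 4, `O=C(/C(=C\c1ccc(O)cc1)SCc1ccc(Cl)cc1)c1ccc(Cl)cc1`, is the compound yet to be measured. Its difference from compound 2 is 4-hydroxyphenyl in place of 1H-pyrrol-2-yl on a double-bonded chain carbon bound to a double-bonded chain carbon. Within the data shown here, no measured step touches this position directly; the only measured step, from compound 1 to compound 2, changes the group on the sulfur and is flat. Compound 3, which also bears a substituted phenyl on the double-bonded chain carbon, sits at the same value as compound 2, which points to no step beyond the scatter. Compound 4 is therefore expected to show a step of no change at the digits printed from compound 2 to compound 4 (within the scatter), with an estimate of 10000 nM and a range from 3000 nM to 20000 nM.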

Compound 4, concentration for 50% growth inhibition: 10000 nM
Compound 4: the middle estimate sits on the measured number at the digits printed; the range from low to high includes it.
By their numbers in this assay, from the lowest: compounds 1, 2, 3 and 4 (each within the scatter of the next).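

In this assay, putting 4-hydroxyphenyl in place of 1H-pyrrol-2-yl on a double-bonded chain carbon bound to a double-bonded chain carbon gives no change at the digits printed from compound 2 to compound 4 (within the scatter). Among these compounds, the earlier step changed only the group on the sulfur, so this is the first reading at this position, and it shows that a six-membered aromatic ring of carbon only can stand where a five-membered aromatic ring with 1 hetero atom stood without the number moving beyond the scatter. Nothing at hand accounts for this flat result.

From the compounds shown here alone, it remains open whether any group at this position can move the number away from the value shared by these compounds, for instance a phenyl ring carrying a dimethylamino group or a carboxylic acid, or a plain alkyl chain in place of the ring. Going by these compounds, it is also open whether the swap of 1H-pyrrol-2-yl for 4-hydroxyphenyl would stay equally flat with a group other than 4-chlorobenzyl on the sulfur, since both compounds of this step carry that same group.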